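Swapping a phenol for a benzoic acid on a diterpenoid amine

The source may report more compounds than this note shows. Statements on the series, on what has been measured and on what is new or still open speak of the compounds shown alone.

Measured so far:
compound 1 `C=C1[C@@H](OC(C)=O)C[C@@H]2[C@](C)(COC=O)[C@H](OC(C)=O)CC[C@@]2(C)[C@@H]1C[C@@H](Nc1ccc(O)cc1)C1=CCOC1=O` — 28900 nM
compound 2 `C=C1[C@@H](OC(C)=O)C[C@@H]2[C@](C)(CO[Si](C)(C)C(C)(C)C)[C@H](OC(C)=O)CC[C@@]2(C)[C@@H]1C[C@@H](Nc1ccc(O)cc1)C1=CCOC1=O` — 8350 nM

Both values come from a functional assay on KB cells (Homo sapiens) for cytotoxicity, read by sulforhodamine B assay; on this read-out higher numbers stand for weaker inhibition and lower numbers for stronger inhibition. Compound 1 stands with the highest number of the two; its nearest neighbour is compound 2, and the change from one to the other, a 3.5-fold lower number from compound 1 to compound 2 (0.54 log units; beyond the scatter), concerns only the side chain on the saturated carbon of the shared core.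

Compound 3 `C=C1[C@@H](OC(C)=O)C[C@@H]2[C@](C)(COC=O)[C@H](OC(C)=O)CC[C@@]2(C)[C@@H]1C[C@@H](Nc1ccc(C(=O)O)cc1)C1=CCOC1=O` keeps the core and side chain of compound 1 and alters only the aromatic ring on the amine: carboxy in place of hydroxy on an aromatic carbon. Going by the values given here, no measured step touches this ring, so the single measured step gives no guide to the direction or size of the change. With nothing to lean on, the expectation is a step no larger than the usual scatter, so that for compound 3 the estimate is 30000 nM (range 10000 nM to 90000 nM), an expected step of a 1.0-fold higher number from compound 1 to compound 3 (0.02 log units; within the scatter).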

Compound 3, half-maximal inhibitory concentration: > 50000 nM
Compound 3 was reported as a limit; the forecaster's own chance of this, stated with the estimate: 15%; at least 1.6-fold (0.22 log units) between middle value and limit.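

Compound 3 is reported only as a limit, not as a number: the limit of > 50000 nM in this assay, at which 1 of the 3 values shown sits. Placing carboxy in place of hydroxy on the aromatic ring gives an at least 1.7-fold higher number from compound 1 to compound 3 (0.23 log units; that floor lies within the scatter) in this assay, so this is the first look at the ring on the amine, and the change brings no sign of stronger inhibition. Going by these compounds, because the value is a limit, the real size of the step stays unknown, and its floor alone does not separate the two compounds.

The compounds shown leave open whether a methyl ester, an amide or an amine on the same aromatic carbon would behave like hydroxy or like carboxy. They also leave open how carboxy on the ring would fare with the silyl-bearing side chain of compound 2.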